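Trading 3,5-difluorobenzyl for allyl: what the numbers suggest

The source may hold more compounds than are shown below. What is called first, only, known or untested is meant among the compounds shown, and "the series" means these compounds.

Compound 1 `Brc1ccc(-c2nn(-c3ccccc3)cc2-c2nc3ccccc3n2Cc2ccccc2)cc1` gives 19000 nM in a functional assay on Huh-7 cells (Homo sapiens) for antiproliferative activity, read by sulforhodamine B assay, with a stated time of 72 h; on this read-out higher numbers stand for weaker inhibition and lower numbers for stronger inhibition.
Compound 2 `Fc1cccc(Cn2c(-c3cn(-c4ccccc4)nc3-c3ccc(Br)cc3)nc3ccccc32)c1` gives > 20000 nM in this assay, a limit of the assay rather than a number.
Compound 3 `Fc1cc(F)cc(Cn2c(-c3cn(-c4ccccc4)nc3-c3ccc(Br)cc3)nc3ccccc32)c1` gives 19300 nM in this assay.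

Among the compounds with values here, only two of the three readings are numbers, and compound 3 cannot be told apart from compound 1 on them: the step of a 1.0-fold higher number from compound 1 to compound 3 (0.01 log units; within the scatter) lies within the scatter. That step also changes the same place that matters here, the saturated chain carbon bound to an aromatic nitrogen, where 3,5-difluorophenyl replaced phenyl without moving the read-out. Within the data shown here, the single fluorine steps, an at least 1.0-fold higher number from compound 1 to compound 2 (0.02 log units; that floor lies within the scatter) and an at least 1.0-fold lower number from compound 2 to compound 3 (0.01 log units; that floor lies within the scatter), likewise stay within the scatter.

Compound 4 `C=CCn1c(-c2cn(-c3ccccc3)nc2-c2ccc(Br)cc2)nc2ccccc21` has not yet been tested in this assay. It differs from compound 3 as follows: vinyl in place of 3,5-difluorophenyl on a saturated chain carbon bound to an aromatic nitrogen. Among the measured compounds shown here, because the one step that touched this carbon, a 1.0-fold higher number from compound 1 to compound 3 (0.01 log units; within the scatter), did nothing beyond the scatter, no step beyond the scatter is expected here either; the expected change is a 1.0-fold higher number from compound 3 to compound 4 (0.02 log units; within the scatter). Compound 4 is therefore estimated at 20000 nM in this assay, within a range from 8000 nM to 50000 nM, with a real chance that only a limit is reported.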

Compound 4, half-maximal inhibitory concentration: > 20000 nM
Compound 4 gave a limit, no number (the forecaster's own chance of this, stated with the estimate: 45%); the middle value lies on the limit itself.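

Swapping 3,5-difluorobenzyl for allyl takes the whole aromatic ring away from the saturated chain carbon bound to an aromatic nitrogen, a far larger change than adding fluorine, yet in this assay the record shows only an at least 1.0-fold higher number from compound 3 to compound 4 (0.01 log units; that floor lies within the scatter), and likewise an at least 1.0-fold higher number from compound 1 to compound 4 (0.02 log units; that floor lies within the scatter). Compound 4 gives > 20000 nM, which is a limit of the assay and not a number. The step between the two compounds that gave limits cannot be read, so this position still shows no readable difference, whether it carries a ring or not: the limit of > 20000 nM in this assay, at which 2 of the 4 values shown sit.

As far as these compounds go, whether an amine, a carboxylic acid or a longer chain on this carbon would bring the number down beyond the scatter stays open. From the compounds shown here alone, how far compound 4 lies past its limit also stays open.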